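The source may report more compounds than this note shows. Statements on the series, on what has been measured and on what is new or still open speak of the compounds shown alone.

Compound 1 `Oc1cccc(/C=N/n2c(S)nnc2-c2cnccn2)c1`: 151000 nM
Compound 2 `Sc1nnc(-c2cnccn2)n1/N=C/c1ccc(Cl)cc1`: 218000 nM

Going by the values given here, both values come from an ADME assay on NIH3T3 cells (Mus musculus) for cytotoxicity, read by MTT assay, with a stated time of 24 h (on this read-out higher numbers stand for weaker inhibition and lower numbers for stronger inhibition), where compound 2 lies within the scatter of compound 1, the only other measured compound. Compound 3 `Cc1ccc(/C=N/n2c(S)nnc2-c2cnccn2)cc1` differs from compound 2 by methyl in place of chloro on an aromatic carbon. Among the compounds with values here, the one measured step, a 1.4-fold higher number from compound 1 to compound 2 (0.16 log units; within the scatter), put 4-chlorophenyl in place of 3-hydroxyphenyl. It does not test this exact change, but on that evidence no step beyond the scatter is expected in this assay. The expected change is a 1.1-fold lower number from compound 2 to compound 3 (0.06 log units; within the scatter). For compound 3 the estimated value is 190000 nM, with an expected range of 90000 nM to 400000 nM.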

Compound 3, half-maximal inhibitory concentration: 156000 nM
For compound 3 the middle estimate is 1.2-fold (0.09 log units) above the measured one, and the stated range covers the measured number.
By their numbers in this assay, from the lowest: compounds 1, 3 and 2 (each within the scatter of the next).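

Replacing chloro with methyl on the aromatic carbon para to a large group gives a 1.4-fold lower number from compound 2 to compound 3 (0.15 log units; within the scatter) in this assay, the first direct test of this change at this position. The step from 3-hydroxyphenyl to 4-methylphenyl gives a 1.0-fold higher number from compound 1 to compound 3 (0.01 log units; within the scatter), so all three aryl groups shown lie within the scatter of one another. Nothing available offers an explanation for this result.

As far as these compounds go, whether an amine, a carboxylic acid or a longer chain at this position would move the number beyond the scatter remains open. So does whether any change to the shared core would do so.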